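The compounds below may be only part of what the source reports. "The series", "measured", "known", "first", "only" and "open" are said of these compounds alone.

Compound 3 `CC(C)c1n[nH]c2c(NCc3ccc(-c4ccccn4)cc3)nc(SC(CO)C(C)C)nc12` gives 980 nM in a functional assay on HT cells (Homo sapiens) for antiproliferative activity, read by fluorescence, with a stated time of 72 h (on this read-out higher numbers stand for weaker inhibition of growth and lower numbers for stronger inhibition of growth), the highest of the three numbers measured. Its nearest neighbour is compound 1 `CC(C)c1n[nH]c2c(NCc3ccc(-c4ccccn4)cc3)nc(SCC(O)C(F)(F)F)nc12`, which gives 690 nM, and the gap a 1.4-fold higher number from compound 1 to compound 3 (0.15 log units; within the scatter) lies within the scatter. Compound 2 `CCC(O)CSc1nc(NCc2ccc(-c3ccccn3)cc2)c2[nH]nc(C(C)C)c2n1` gives 273 nM, and the step of a 3.6-fold higher number from compound 2 to compound 3 (0.56 log units; beyond the scatter) is beyond the scatter. Compound 4 `CC(C)c1n[nH]c2c(NCc3ccc(-c4ccccn4)cc3)nc(SCCO)nc12` differs from compound 3 by hydrogen in place of isopropyl on a saturated chain carbon bound to a saturated chain carbon and a sulfur. The step of a 3.6-fold higher number from compound 2 to compound 3 (0.56 log units; beyond the scatter), likewise a change of the chain on the sulfur, bears most directly on this and was modest; the step of a 2.5-fold lower number from compound 1 to compound 2 (0.40 log units; beyond the scatter) was modest too. Compound 4 is therefore expected to give a modestly lower number, a 2.2-fold lower number from compound 3 to compound 4 (0.34 log units; beyond the scatter). The estimate for compound 4 in this assay is 450 nM, with a range from 200 nM to 1000 nM.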

Compound 4, concentration for 50% growth inhibition: 48 nM
Estimate against measurement, compound 4: 9.4-fold (0.97 log units) above; measured number outside the range, below it.
By their numbers in this assay, from the lowest: compound 4; then compound 2; then compounds 1 and 3 (each within the scatter of the next).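

In this assay, the 2-hydroxyethyl chain on the sulfur gives a 20-fold lower number from compound 3 to compound 4 (1.31 log units; beyond the scatter) and a 14-fold lower number from compound 1 to compound 4 (1.16 log units; beyond the scatter), both large, and a 5.7-fold lower number from compound 2 to compound 4 (0.75 log units; beyond the scatter), which is modest. Hydrogen in place of isopropyl, trifluoromethyl or ethyl thus lowers the number each time, with no compound shown going against this, a pattern the earlier compounds could not reveal. Nothing available here accounts for the size of these steps. As far as these compounds go, it remains open whether a methyl group on this chain would keep the number low, and how a 3-hydroxypropyl chain, an amine or a carboxylic acid in place of the hydroxyl would read.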